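Thiophene replacement on the side-chain aryl group

The source may hold more compounds than are shown below. What is called first, only, known or untested is meant among the compounds shown, and "the series" means these compounds.

For the measured compounds named here, compound 2 `C=C1C(=O)O[C@H]2CC3=C[C@H](C/C(C)=C/[C@@H](OC(=O)/C=C/c4ccc(N(C)C)cc4)[C@H]12)OC3=O` is the weaker of the two measured members. In a functional assay on A549 cells (Homo sapiens) for cytotoxicity, read by MTT assay, with a stated time of 48 h (on this read-out higher numbers stand for weaker inhibition and lower numbers for stronger inhibition), compound 2 sits at a limit, > 10000 nM, with no number inside the range, being (the limit of > 10000 nM in this assay, at which 1 of the 2 values shown sits). Going by the values given here, compound 1 `C=C1C(=O)O[C@H]2CC3=C[C@H](C/C(C)=C/[C@@H](OC(=O)/C=C/c4ccccc4)[C@H]12)OC3=O` gives 4800 nM in this assay, so the only measured step, an at least 2.0-fold higher number from compound 1 to compound 2 (0.31 log units; beyond the scatter), marks a loss on adding the dimethylamino group. Compound 3 `C=C1C(=O)O[C@H]2CC3=C[C@H](C/C(C)=C/[C@@H](OC(=O)/C=C/c4cccs4)[C@H]12)OC3=O` differs from compound 2 as follows: thiophen-2-yl in place of 4-(dimethylamino)phenyl on a double-bonded chain carbon bound to a double-bonded chain carbon. Among the compounds with values here, no measured step covers a thiophen-2-yl, so the expectation leans on compound 1 at 4800 nM: removing the dimethylamino group alone should recover at least the size of an at least 2.0-fold higher number from compound 1 to compound 2 (0.31 log units; beyond the scatter) in the other direction, while the five-membered ring has no measured precedent here. Compound 3 is therefore expected at 6000 nM, with a range of 2500 nM to 15000 nM, close to compound 1. This is an expected at least 1.6-fold lower number from compound 2 to compound 3 (0.22 log units; that floor lies within the scatter), its size uncertain because compound 2 stands only at the limit > 10000 nM.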

Compound 3, half-maximal inhibitory concentration: 4300 nM
Compound 3: the middle estimate sits 1.4-fold (0.14 log units) above what was measured; the range from low to high includes it.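

Thiophen-2-yl and phenyl are interchangeable on this double-bonded chain carbon in this assay, at least for these two rings: a 1.1-fold lower number from compound 1 to compound 3 (0.05 log units; within the scatter). The second step, an at least 2.3-fold lower number from compound 2 to compound 3 (0.36 log units; beyond the scatter), shows that the loss seen with 4-(dimethylamino)phenyl is not shared by every aromatic ring at this place, since compound 1 and compound 3 lie within the scatter of each other. The true size of that second step stays open at one end, as the value of compound 2 is a limit and not a number: the limit of > 10000 nM in this assay, at which 1 of the 3 values shown sits.

As far as these compounds go, it remains open whether a furan-2-yl or a thiophen-3-yl group would match thiophen-2-yl here. Also open, from the compounds shown here alone, is whether a primary amine or a methoxy group on the phenyl ring would bring the same loss as dimethylamino.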